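Aryl sulfamate series: amine variation on the benzamide

The compounds below may be only part of what the source reports. "The series", "measured", "known", "first", "only" and "open" are said of these compounds alone.

Measured so far:
Compound 1, `CCN(Cc1ccc(Br)cc1)c1cccc(C(=O)N2CCc3ccc(OS(N)(=O)=O)cc3C2)c1`: 24.2%
Compound 2, `CC(C)CCN(CCC(C)C)c1cccc(C(=O)N2CCc3ccc(OS(N)(=O)=O)cc3C2)c1`: 32.3%

In an assay on HEK293 cells for inhibition of Steryl-sulfatase (Homo sapiens), tested at 0.1 uM (a higher number here means a stronger effect of the compound at the concentration tested, a lower number a weaker effect), compound 1 gives 24.2% and compound 2 gives 32.3%. Going by the values given here, compound 2 holds the larger of the two numbers, but the only step between them, a number 8.1 percentage points higher from compound 1 to compound 2 (within the scatter), does not exceed the scatter, so the two compounds cannot be told apart on these data.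

Compound 3, `CCCN(Cc1ccccc1)c1cccc(C(=O)N2CCc3ccc(OS(N)(=O)=O)cc3C2)c1`, is not yet measured. It differs from compound 2 by benzyl(propyl)amino in place of diisopentylamino on an aromatic carbon. Among the compounds with values here, the one measured step, from compound 1 to compound 2, exchanged the same amine position and stayed within the scatter; compound 1 already carries a benzyl-type amine close in kind to that of compound 3, and compound 1 gives 24.2%. No step beyond the scatter is therefore expected in this assay for compound 3.

Compound 3 is estimated at 27% in this assay, with a range of 14% to 40%, which means an expected step of a number 5.3 percentage points lower from compound 2 to compound 3 (within the scatter).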

Compound 3, a percentage reported as inhibition, at one concentration (the size of the read-out at that concentration, not a potency): 23.1%
Compound 3: the middle estimate sits 3.9 percentage points above what was measured, and the stated range covers the measured number.
By their numbers in this assay, from the lowest: compounds 3, 1 and 2 (each within the scatter of the next).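

With compound 3 the set now spans three amines on this aromatic carbon, and in this assay none of the steps between them can be separated from the scatter. Replacing diisopentylamino with benzyl(propyl)amino keeps the heavy-atom count and adds a six-membered aromatic ring of carbon only, yet it gives a number 9.2 percentage points lower from compound 2 to compound 3 (within the scatter), so the presence of that ring on the amine does not by itself distinguish the two compounds. Benzyl(propyl)amino in place of (4-bromobenzyl)(ethyl)amino gives a number 1.1 percentage points lower from compound 1 to compound 3 (within the scatter), so the two benzyl-type amines also cannot be told apart, and no data bear on any explanation for these results.

Still open, going by these compounds, is whether any group at this position can move the read-out beyond the scatter, for example a small dimethylamino group, a piperidine ring or a benzyl group carrying a carboxylic acid. These are also readings at a single concentration, so whether compound 1, compound 2 and compound 3 would separate in a full concentration series remains unanswered.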